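A Methoxy for a Chloro on the Aryl Ring

The source may report more compounds than this note shows. Statements on the series, on what has been measured and on what is new or still open speak of the compounds shown alone.

Compound 2 `Cc1oc(-c2c(Cl)cccc2Cl)nc1CN1CCC(C(=O)NCCCN2C[C@H](C)C[C@H](C)C2)CC1` is one of three compounds tested in an ADME assay on Huh7.5.1 cells (Homo sapiens) for cytotoxicity, read by ATP content, with a stated time of 48 h; on this read-out higher numbers stand for lower toxicity in this test and lower numbers for higher toxicity in this test. In this assay compound 2 gives 13200 nM. Compound 1 `Cc1ccccc1-c1nc(CN2CCC(C(=O)NCCCN3CCC(C)(C)CC3)CC2)c(C)o1` gives 10200 nM in this assay, and compound 3 `Cc1ccccc1-c1nc(CN2CCC(C(=O)N3CCN(C4CCN(C)CC4)CC3)CC2)c(C)o1` gives 19900 nM. Both of those numbers lie within the usual scatter of the value for compound 2, so no order among the three compounds can be read from them; they behave alike on this read-out.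

Compound 4 `COc1cccc(Cl)c1-c1nc(CN2CCC(C(=O)NCCCN3C[C@H](C)C[C@H](C)C3)CC2)c(C)o1` has not yet been measured in this assay. It differs from compound 2 in a single place: methoxy in place of chloro on an aromatic carbon. Among the measured compounds shown here, no pair of measured compounds shows this same change, so there is no step against which to weigh it. Compound 4 is therefore expected to stay within the scatter of compound 2, and the step that this expectation means is estimated as a 1.0-fold lower number from compound 2 to compound 4 (0.01 log units; within the scatter). The estimate for compound 4 in this assay is 13000 nM, with a range from 6000 nM to 28000 nM.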

Compound 4, half-maximal cytotoxic concentration: 15800 nM
Beside the measured number, compound 4's estimate is 1.2-fold (0.08 log units) below it; low and high end bracket the measured number.
By their numbers in this assay, from the lowest: compounds 1, 2, 4 and 3 (each within the scatter of the next).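

In this assay the change from 2,6-dichlorophenyl to 2-chloro-6-methoxyphenyl amounts to a 1.2-fold higher number from compound 2 to compound 4 (0.08 log units; within the scatter). The earlier compounds shown here differed from one another in more than one place, so this pair is the only one that isolates a single change on the aryl ring, and it shows that methoxy in place of chloro at this position, ortho to a large group, leaves the read-out within the scatter. Nothing available explains this outcome.

As far as these compounds go, whether an amine, a hydroxyl or a nitrile at this same position would also stay within the scatter of compound 2 remains open. So does the outcome of replacing the remaining chloro with a second methoxy.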